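A few compounds are considered here, and "the series" means these few. Any claim that something is new, unique, unknown or untested is made for them only; others in the source may bear on it.

Measured so far in a functional assay on MCF7 cells (Homo sapiens) for cytotoxicity, read by MTT assay, with a stated time of 72 h; on this read-out higher numbers stand for weaker inhibition and lower numbers for stronger inhibition:
- compound 1 `Cc1cc(=O)n(-c2ccccc2C(F)(F)F)nc1C(=O)Nc1ccc(Oc2ncnc3ccsc23)cc1`: 5550 nM
- compound 2 `Cc1cc(=O)n(-c2ccc(Br)cc2F)nc1C(=O)Nc1ccc(Oc2ncnc3ccsc23)cc1`: 9360 nM
- compound 3 `Cc1cc(=O)n(-c2ccccc2C(F)(F)F)nc1C(=O)Nc1ccc(Oc2ncnc3sccc23)cc1`: a limit of the assay, > 40000 nM

Compound 3 stands at the assay limit of > 40000 nM in this assay, at which 1 of the 3 values shown sits, and so carries no number, only a floor. Compound 4 `Cc1cc(=O)n(-c2ccc(Br)cc2F)nc1C(=O)Nc1ccc(Oc2ncnc3sccc23)cc1` differs from compound 3 by 4-bromo-2-fluorophenyl in place of 2-(trifluoromethyl)phenyl on an aromatic nitrogen. The same exchange has been measured once, on the other core: a 1.7-fold higher number from compound 1 to compound 2 (0.23 log units; within the scatter). That step lies within the scatter, so in this assay no step beyond the scatter is expected from compound 3 to compound 4, and compound 4 is expected to remain at or near the limit. Compound 4 is therefore estimated at 60000 nM, within 30000 nM to 150000 nM, which means an expected step that the limit leaves unreadable from compound 3 to compound 4.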

Compound 4, half-maximal inhibitory concentration: 15200 nM
Beside the measured number, compound 4's estimate is 3.9-fold (0.60 log units) above it; the measured number lies below the stated range.
By their numbers in this assay, from the lowest: compounds 1, 2 and 4 (each within the scatter of the next, the first and the last beyond it). At a limit, above all of these: compound 3.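

In this assay, 4-bromo-2-fluorophenyl in place of 2-(trifluoromethyl)phenyl on the aromatic nitrogen gives an at least 2.6-fold lower number from compound 3 to compound 4 (0.42 log units; beyond the scatter), a step read from a limit, so the effect of this exchange depends on the core: the same change on two cores in this assay, a 1.7-fold higher number (0.23 log units; within the scatter) from compound 1 to compound 2 and an at least 2.6-fold lower number (0.42 log units; beyond the scatter) from compound 3 to compound 4, at least 4.4-fold (0.64 log units) apart, beyond the scatter of two such steps

The exchange of cores, beyond the scatter with 2-(trifluoromethyl)phenyl, stays within it with 4-bromo-2-fluorophenyl, at a 1.6-fold higher number from compound 2 to compound 4 (0.21 log units; within the scatter): the same change on two cores in this assay, an at least 7.2-fold higher number (0.85 log units; beyond the scatter) from compound 1 to compound 3 and a 1.6-fold higher number (0.21 log units; within the scatter) from compound 2 to compound 4, at least 4.4-fold (0.64 log units) apart, beyond the scatter of two such steps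

The compounds shown do not separate the contributions of the bromine and the fluorine. On these data alone, it also remains open how either core responds to a phenyl carrying an amine or a carboxylic acid on this nitrogen, or to a longer alkyl chain there.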